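The compounds below may be only part of what the source reports. "The series", "measured", "known", "first", "only" and "open" are said of these compounds alone.

Working notes on the series. In a functional assay on CHO cells for agonist activity at Free fatty acid receptor 1 (Homo sapiens), read by FLIPR and calcium flux (on this read-out higher numbers stand for an effect only at larger amounts of compound and lower numbers for an effect already at smaller amounts), compound 2 `Cc1ccccc1-c1cccc(COc2ccc(S(=O)(=O)CC(=O)O)cc2)c1` gives 46.8 nM. Going by the values given here, the only other measured member, compound 1 `Cc1cccc(C)c1-c1cccc(COc2ccc(S(=O)(=O)CC(=O)O)cc2)c1`, gives 66.1 nM in this assay, and the step of a 1.4-fold lower number from compound 1 to compound 2 (0.15 log units; within the scatter) leaves the two numbers indistinguishable; compound 2 therefore stands level with compound 1 on what has been measured so far, with nothing to separate them. Compound 3 `O=C(O)CS(=O)(=O)c1ccc(OCc2cccc(-c3ccccc3F)c2)cc1` is the next member and awaits measurement in this assay. Its change from compound 2 is fluoro in place of methyl on an aromatic carbon. Among the compounds with values here, no measured step exchanges methyl for fluoro; the single step at hand, a 1.4-fold lower number from compound 1 to compound 2 (0.15 log units; within the scatter), only removes a methyl and stays within the scatter, so the series offers no precedent for the direction of this exchange. A shift beyond the scatter in this assay is consequently not expected in either direction, though the lack of a matched precedent keeps the range wide. For compound 3 the expected value in this assay is 70 nM, with a range from 25 nM to 200 nM. The step of a 1.5-fold higher number from compound 2 to compound 3 (0.17 log units; within the scatter) is accordingly estimated to be small.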

Compound 3, half-maximal effective concentration: 257 nM
For compound 3 the middle estimate is 3.7-fold (0.56 log units) below the measured one; the measured number lies above the stated range.
By their numbers in this assay, from the lowest: compounds 2 and 1 (each within the scatter of the next); then compound 3.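

Going by these compounds alone, at this position, on an aromatic carbon ortho to a large group, the exchange of methyl for fluoro is not neutral in this assay: it gives a 5.5-fold higher number from compound 2 to compound 3 (0.74 log units; beyond the scatter), whereas the only earlier step, the removal of a methyl elsewhere on that ring, gave a 1.4-fold lower number from compound 1 to compound 2 (0.15 log units; within the scatter). Replacing 2,6-dimethylphenyl with 2-fluorophenyl gives a 3.9-fold higher number from compound 1 to compound 3 (0.59 log units; beyond the scatter), so compound 1 and compound 2, which cannot be told apart, both carry lower numbers than compound 3, and among these three compounds only the one without a methyl on this ring stands apart. No evidence on hand bears on the reason for this shift.

The compounds shown leave open whether the higher number belongs to fluoro itself or simply to the absence of methyl at this position, a question that a plain phenyl ring with hydrogen there would address. From the compounds shown here alone, it also remains open whether a 2-chlorophenyl or 2-methoxyphenyl group would read with compound 2 or with compound 3 in this assay.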